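Benzyl in place of oxan-4-yl: an expected step

The source may hold more compounds than are shown below. What is called first, only, known or untested is meant among the compounds shown, and "the series" means these compounds.

Measured so far:
compound 1 `Cc1cc(NC(=O)Cn2nnc(-c3ccccc3)n2)n(C2CCOCC2)n1` — 435 nM
compound 2 `O=C(Cn1nnc(-c2ccccc2)n1)Nc1cc(C2(C(F)(F)F)CC2)nn1C1CCCCC1` — "not active" (no number reported)

Within the data shown here, in an assay on HEK293 cells for activation of Kir3.1/Kir3.2 (Homo sapiens), read by thallium flux (a higher number here means that more compound is needed for the effect, a lower number that less compound is needed), compound 1 gives 435 nM, the only number available. In this assay compound 2 is reported as "not active" (no number reported), without a number. Compound 3 `Cc1cc(NC(=O)Cn2nnc(-c3ccccc3)n2)n(Cc2ccccc2)n1` differs from compound 1 by benzyl in place of oxan-4-yl on an aromatic nitrogen. Among the measured compounds shown here, no step between measured compounds is known, so the expectation rests on compound 1 alone: the change is expected to be a 2.1-fold higher number from compound 1 to compound 3 (0.32 log units; beyond the scatter), likely a little beyond the scatter toward more compound being needed. Compound 3 is expected to give 900 nM in this assay, within 200 nM to 4000 nM.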

Compound 3, half-maximal effective concentration: 495 nM
Compound 3: middle estimate off by 1.8-fold (0.26 log units), on the high side; the measured number falls inside the stated range.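

The step of a 1.1-fold higher number from compound 1 to compound 3 (0.06 log units; within the scatter) in this assay shows that, on this aromatic nitrogen, benzyl can replace oxan-4-yl without a change beyond the scatter. A six-membered aromatic ring of carbon only is thus tolerated here as well as a six-membered non-aromatic ring with an oxygen, although the linking carbon of benzyl also differs. No measured evidence bears on why the two groups read alike.

Still open, on these data alone, is how this nitrogen responds to a chain ending in an amine or a carboxylic acid. As far as these compounds go, whether a benzyl ring bearing fluorine or methoxy would keep this level also remains unknown.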